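One group swapped on a sulfonamide nitrogen

The source may hold more compounds than are shown below. What is called first, only, known or untested is meant among the compounds shown, and "the series" means these compounds.

In a physicochemical assay for lipophilicity, at pH 7.4 (on this read-out lower numbers stand for lower lipophilicity and higher numbers for higher lipophilicity), compound 1 `CC(C)CN(c1cc2ccccc2s1)S(=O)(=O)c1ccc2c(c1)C(=O)CC(C1CCOCC1)O2` gives 4.01 and compound 2 `CCc1ccc(N(CC(C)C)S(=O)(=O)c2ccc3c(c2)C(=O)CC(C2CCOCC2)O3)cc1` gives 4.21, so these two values lie within the usual scatter of each other. Compound 3 `CC(C)CN(Cc1ccccc1C(F)(F)F)S(=O)(=O)c1ccc2c(c1)C(=O)CC(C1CCOCC1)O2` has not yet been measured. It carries 2-(trifluoromethyl)benzyl in place of 4-ethylphenyl on a sulfonamide nitrogen. Going by the values given here, only one measured step involves a swap at this nitrogen, with 4-ethylphenyl in place of 1-benzothiophen-2-yl, and it is small: a number 0.20 log units higher from compound 1 to compound 2 (within the scatter). Resting on that single step, no shift beyond the scatter is expected in this assay. The expected move is a number 0.09 log units higher from compound 2 to compound 3 (within the scatter). One step with a different incoming group is thin evidence, so the range is kept wide. For compound 3 the estimated value is 4.3, with an expected range of 3.8 to 4.8.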

Compound 3, distribution coefficient: 4.32
For compound 3 the middle estimate is 0.02 log units below the measured one, and the stated range covers the measured number.
By their numbers in this assay, from the lowest: compounds 1, 2 and 3 (each within the scatter of the next, the first and the last beyond it).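

In this assay the swap of 4-ethylphenyl for 2-(trifluoromethyl)benzyl, which brings 11 heavy atoms including 3 fluorine in place of 8 carbon, comes out as a number 0.11 log units higher from compound 2 to compound 3 (within the scatter) and so does not separate these two groups. Set against 1-benzothiophen-2-yl, the same incoming group gives a number 0.31 log units higher from compound 1 to compound 3 (beyond the scatter) and this is the first step at this sulfonamide nitrogen to pass the scatter, though only modestly. No separate measurement is available to explain these numbers.

The compounds shown do not tell whether the trifluoromethyl group matters here, which a plain benzyl group at the same nitrogen would test. They also leave open how far this read-out would move with a group of a different kind on that nitrogen, such as an amine or a carboxylic acid.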